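Swapping an Amide for a Pyrazole on the Shared Core

This account rests on a few compounds, and the source may have more. Where it says the series, first, only, none or still open, it means among the compounds named here.

Among the compounds with values here, compound 1 `CNC(=O)c1cncc(-c2ccc(C(N)=O)c(OC(C)C)c2)c1` gives 1900 nM in an assay on cells for inhibition of MAP kinase-interacting serine/threonine-protein kinase 1 (Homo sapiens), read by mobility shift assay, with stated times of 10 min and 60 min, in the presence of a further agent that is not named here (a lower number here means a stronger inhibitor, a higher number a weaker inhibitor), the lowest of the three numbers measured so far. Compound 2 `NC(=O)c1ccc(-c2cccnc2)cc1O` gives 4300 nM in this assay, a gap from compound 1 that lies beyond the usual scatter, and compound 3 `Cc1ncccc1-c1ccc(C(N)=O)cc1` gives 170000 nM, far weaker than either. Compound 4 `Cc1c(-c2cncc(-c3ccc(C(N)=O)c(OC(C)C)c3)c2)cnn1C` has not yet been tested. It differs from compound 1 in a single place: 1,5-dimethyl-1H-pyrazol-4-yl in place of methylcarbamoyl on an aromatic carbon. Within the data shown here, no measured pair shows this change, so the data give no anchor for its effect. The step of a 1.3-fold lower number from compound 1 to compound 4 (0.10 log units; within the scatter) is expected to be small, in either direction, within or only just beyond the scatter. Compound 4 is therefore estimated at 1500 nM, with a likely range from 400 nM to 6000 nM.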

Compound 4, half-maximal inhibitory concentration: 60 nM
For compound 4 the middle estimate is 25-fold (1.40 log units) above the measured one, and the stated range ends above it.
By their numbers in this assay, from the lowest: compound 4; then compound 1; then compound 2; then compound 3.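

At this position, on an aromatic carbon two atoms from the ring nitrogen, putting 1,5-dimethyl-1H-pyrazol-4-yl in place of methylcarbamoyl gives a 32-fold lower number from compound 1 to compound 4 (1.50 log units; beyond the scatter) in this assay, a large step. The number here therefore depends strongly on this group, and the hydrogen-bond donor of methylcarbamoyl is not required for a low number. Nothing shown explains why the number falls so far. Going by these compounds, it remains open whether the two methyl groups on the pyrazole contribute to this step, and whether an unsubstituted pyrazole, an amine or a carboxylic acid at this position would give a similar number.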